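Swapping the Aryl on a Sulfonyl Sulfur: Distribution Volume

The compounds below may be only part of what the source reports. "The series", "measured", "known", "first", "only" and "open" are said of these compounds alone.

Measured so far:
compound 1 `N#Cc1ccc(O[C@H]2CN(S(=O)(=O)c3ccc(C(F)(F)F)nc3)C[C@@]2(O)CO)cc1F`: 4.1 L/kg
compound 2 `N#Cc1ccc(O[C@H]2CN(S(=O)(=O)c3ccc(Cl)cn3)C[C@@]2(O)CN)cc1F`: 6.7 L/kg
compound 3 `N#Cc1ccc(O[C@H]2CN(S(=O)(=O)c3ccc(Cl)cc3Cl)C[C@@]2(O)CN)cc1F`: 7.7 L/kg

These three compounds share a core and differ in the aryl group on the sulfonyl sulfur and in the small group on the ring carbon that carries the hydroxyl. In an ADME assay on the whole organism (Rattus norvegicus, strain Sprague-Dawley) for pharmacokinetics, read by LC-MS, with a stated time of 30 min (a higher number here means that more of the compound sits outside the plasma, a lower number that more of the compound stays in the plasma), compound 1 gives 4.1 L/kg, the lowest of the three numbers, yet its gaps to compound 2 and to compound 3 both fall within the usual scatter, so no order among them can be claimed.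

Among the compounds with values here, the one measured step, a 1.1-fold higher number from compound 2 to compound 3 (0.06 log units; within the scatter), is an aryl swap on the same sulfonyl sulfur, and it changed nothing beyond the scatter. Compound 4 `N#Cc1ccc(O[C@H]2CN(S(=O)(=O)c3ccccc3C#N)C[C@@]2(O)CO)cc1F` arises from compound 1 by another such swap: 2-cyanophenyl in place of 6-(trifluoromethyl)pyridin-3-yl on a sulfonyl sulfur. The measured step shares the place of change but not the groups involved, and it concerned compounds with a different small group on the core, so it bears only loosely on the question.

With that single precedent pointing to no change, compound 4 is expected to show a step of a 1.2-fold lower number from compound 1 to compound 4 (0.07 log units; within the scatter), within the scatter. The estimate for compound 4 in this assay is 3.5 L/kg, ranging from 1.6 L/kg to 7.5 L/kg.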

Compound 4, volume of distribution at steady state: 0.9 L/kg
For compound 4 the middle estimate is 3.9-fold (0.59 log units) above the measured one; the measured number lies below the stated range.
By their numbers in this assay, from the lowest: compound 4; then compounds 1, 2 and 3 (each within the scatter of the next).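

In this assay the aryl on the sulfonyl sulfur proves able to move the number: 2-cyanophenyl in place of 6-(trifluoromethyl)pyridin-3-yl gives a 4.6-fold lower number from compound 1 to compound 4 (0.66 log units; beyond the scatter) and so lies clearly outside the ordinary spread of repeat measurements. The earlier swap at this place, a 1.1-fold higher number from compound 2 to compound 3 (0.06 log units; within the scatter), stayed within that spread, so a change of aryl here does not always leave the number where it was. That earlier swap involved other aryl groups on compounds with a different small group on the core, so this contrast describes these two pairs and sets no general rule, and nothing measured here accounts for the size of the new step.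

The swap removes the trifluoromethyl group and the ring nitrogen and adds a nitrile all at once, so the compounds shown leave open which of these changes matters; a plain phenyl group on the same sulfur would help to separate them. Also open, going by these compounds, is whether 2-cyanophenyl would give a similar step on the core of compound 2, which carries an aminomethyl group in place of the hydroxymethyl group of compound 1.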